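The source may report more compounds than this note shows. Statements on the series, on what has been measured and on what is new or still open speak of the compounds shown alone.

Measured compounds:
compound 1 `Cn1nnnc1SCC(=O)N/N=C/c1ccccc1` — 3160000 nM
compound 2 `Cn1nnnc1SCC(=O)N/N=C/c1ccccc1O` — a limit only

For the measured compounds named here, in a functional assay on A549 cells (Homo sapiens) for cytotoxicity, read by XTT assay, with a stated time of 24 h (on this read-out lower numbers stand for stronger inhibition and higher numbers for weaker inhibition), compound 1 gives 3160000 nM, the only plain number among the measured compounds. Compound 2 reaches no number and is reported only as a limit, > 10000000 nM. Going by the values given here, the one measured step, hydroxy in place of hydrogen on an aromatic carbon, gives an at least 3.1-fold higher number from compound 1 to compound 2 (0.50 log units; beyond the scatter), and its size is bounded by the limit of > 10000000 nM in this assay, at which 1 of the 2 values shown sits.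

Compound 3 `Cc1cccc(/C=N/NC(=O)CSc2nnnn2C)c1` differs from compound 1 by methyl in place of hydrogen on an aromatic carbon. The measured step concerns a hydroxy group rather than a methyl group, so it bears on this change only loosely and points, if anywhere, toward a weaker or unchanged result. The step from compound 1 to compound 3 is therefore expected to be a 1.3-fold higher number from compound 1 to compound 3 (0.10 log units; within the scatter), small or within the scatter. Compound 3 is estimated at 4000000 nM, with a range from 1500000 nM to 12000000 nM.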

Compound 3, half-maximal inhibitory concentration: 2000000 nM
Beside the measured number, compound 3's estimate is 2.0-fold (0.30 log units) above it, and the stated range covers the measured number.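

In this assay the methyl change gives a 1.6-fold lower number from compound 1 to compound 3 (0.20 log units; within the scatter), so a methyl group on this aromatic carbon, meta to a large group, leaves the result indistinguishable from that of compound 1. Unlike compound 2, which is reported only as a limit, compound 3 gives a plain number, so a substituent on this ring does not always push the value out of measurable range. Nothing in the data shown explains why the methyl and hydroxy changes end so differently.

As far as these compounds go, it remains open whether an amine, a carboxylic acid or a longer chain on this same carbon would move the number beyond the scatter. From the compounds shown here alone, it is also open whether a methyl group elsewhere on the ring would behave as it does here.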